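The source may report more compounds than this note shows. Statements on the series, on what has been measured and on what is new or still open speak of the compounds shown alone.

Working notes on the series. Compound 1 `CCNc1cc(Nc2cccc(Cl)c2)ncn1` gives in an assay for inhibition of Receptor tyrosine-protein kinase erbB-3 variant L858R (Homo sapiens), read by mobility shift assay, with a stated time of 10 min (a higher number here means a weaker inhibitor, a lower number a stronger inhibitor), only a limit, > 10000 nM, and so sits at the limit of > 10000 nM in this assay, at which 1 of the 2 values shown sits. Going by the values given here, compound 2 `COc1ccc(OC)c(Nc2cc(Nc3ccc(F)cc3)ncn2)c1` gives 230 nM in this assay, the only numerical value in the set so far. Compound 3 `COc1cccc(Nc2cc(Nc3cc(OC)ccc3OC)ncn2)c1` has not been measured; it differs from compound 2 by 3-methoxyphenyl in place of 4-fluorophenyl on a nitrogen on an aromatic ring. Among the compounds with values here, no measured pair isolates this change. The step in this assay is expected to stay within the usual scatter, with no clear direction, estimated as a 1.3-fold higher number from compound 2 to compound 3 (0.12 log units; within the scatter). Compound 3 is accordingly estimated at 300 nM, with a range from 100 nM to 1000 nM.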

Compound 3, half-maximal inhibitory concentration: 18 nM
The estimate for compound 3 lay 17-fold (1.22 log units) above the measured number; the whole stated range lies above it.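

On the nitrogen on an aromatic ring, the choice of aryl group matters strongly: in this assay 3-methoxyphenyl in place of 4-fluorophenyl gives a 13-fold lower number from compound 2 to compound 3 (1.11 log units; beyond the scatter). The entering group carries one hydrogen-bond acceptor where the leaving group has none, but a single pair cannot separate this from the other differences between the two groups. No measurement shown bears on the reason for the step.

As far as these compounds go, whether a plain phenyl or an ethoxy group in place of the methoxy would keep this stronger inhibition stays open. So does whether the step holds with other groups on the shared core.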